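The source may report more compounds than this note shows. Statements on the series, on what has been measured and on what is new or still open speak of the compounds shown alone.

Measured in a functional assay on MCF7 cells (Homo sapiens) for antiproliferative activity, read by MTT assay, with a stated time of 48 h (on this read-out higher numbers stand for weaker inhibition and lower numbers for stronger inhibition), so far:
compound 1 `O=C(N[C@@H](CCCCCCSSc1ccccn1)C(=O)Nc1ccccc1-c1ccccc1)OCc1ccccc1` gives 20800 nM
compound 2 `O=C(N[C@@H](CCCCCCSSc1ccccn1)C(=O)Nc1ccc(-c2ccccc2)cc1)OCc1ccccc1` gives 18100 nM
compound 3 `O=C(N[C@@H](CCCCCCSSc1ccccn1)C(=O)OCc1cccc([N+](=O)[O-])c1)OCc1ccccc1` gives 15200 nM

Compound 3 stands at 15200 nM and lies within the scatter of both other values, so the three do not separate. The unmeasured compound 4 `O=C(N[C@@H](CCCCCCSSc1ccccn1)C(=O)OCc1cccc2ccccc12)OCc1ccccc1` differs from compound 3 by naphthalen-1-yl in place of 3-nitrophenyl on a saturated chain carbon bound to an oxygen next to a carbonyl group. Counted out, the change is naphthalen-1-yl in place of 3-nitrophenyl on a saturated chain carbon bound to an oxygen next to a carbonyl group at that place.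

For the measured compounds named here, no measured step covers this swap directly. Going by the values given here, the only measured step is a 1.1-fold lower number from compound 1 to compound 2 (0.06 log units; within the scatter) for 4-phenylphenyl in place of 2-phenylphenyl on an amide-type nitrogen, which is a different place, and it stays within the scatter. No step beyond the scatter is therefore expected in this assay for this change. The expected step is a 1.0-fold lower number from compound 3 to compound 4 (0.01 log units; within the scatter) in this estimate. Compound 4 is estimated at 15000 nM with an expected range from 7000 nM to 30000 nM for a single measurement.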

Compound 4, half-maximal inhibitory concentration: 15300 nM
Estimate against measurement, compound 4: 1.0-fold (0.01 log units) below, within the range that was stated.
By their numbers in this assay, from the lowest: compounds 3, 4, 2 and 1 (each within the scatter of the next).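

In this assay there is a 1.0-fold higher number from compound 3 to compound 4 (0.00 log units; within the scatter), the only step shown on a saturated chain carbon bound to an oxygen next to a carbonyl group; the one other step lies on an amide-type nitrogen. At this place, replacing 3-nitrophenyl, with its 2 hydrogen-bond acceptors, by naphthalen-1-yl, with none and with a second six-membered aromatic ring of carbon only, gives a step within the scatter. No supporting measurement bears on why this exchange leaves the number within the scatter.

Open, from the compounds shown here alone, is whether an amine, a carboxylic acid or a longer chain in place of these aryl groups would give a step beyond the scatter. Also open, going by these compounds, is whether any change elsewhere on the shared core would separate the values.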